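The compounds below may be only part of what the source reports. "The series", "measured", "known", "first", "only" and "open" are said of these compounds alone.

In a functional assay on the whole organism with Mus musculus as the target (on this read-out lower numbers stand for an effect already at smaller amounts and higher numbers for an effect only at larger amounts of compound), compound 1 (`COc1cc2c(cc1OC)C(c1ccc(Br)cc1)=NNC(=O)C2`) gives 82.5 umol/kg. Compound 2 (`COc1cc2c(cc1OC)C(c1ccc([N+](=O)[O-])cc1)=NNC(=O)C2`) carries nitro where compound 1 carries bromo. Compound 2 reaches only a limit, > 120 umol/kg, and no number.

The next structure, compound 3 (`COc1cc2c(cc1OC)C(c1ccc(Cl)cc1)=NNC(=O)C2`), changes that same place: chloro in place of nitro on an aromatic carbon. This puts chloro in place of nitro, para to a large group.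

Among the measured compounds shown here, only one measured step bears on this change: an at least 1.4-fold higher number from compound 1 to compound 2 (0.16 log units; that floor lies within the scatter). For the measured compounds named here, it gives a floor and no true size, and no measured step has chloro entering. Compound 1, at 82.5 umol/kg, is therefore the nearest guide, and a moderate, poorly defined move to a lower number is expected in this assay. The estimated step is an at least 1.4-fold lower number from compound 2 to compound 3 (0.14 log units; that floor lies within the scatter). For compound 3 the estimate is 85 umol/kg, with an expected range of 45 umol/kg to 145 umol/kg.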

Compound 3, dose for half-maximal effect: 75.3 umol/kg
Beside the measured number, compound 3's estimate is 1.1-fold (0.05 log units) above it; low and high end bracket the measured number.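

Chloro and bromo at this place, para to a large group, cannot be told apart in this assay: the comparison gives a 1.1-fold lower number from compound 1 to compound 3 (0.04 log units; within the scatter). Chloro in place of nitro gives an at least 1.5-fold lower number from compound 2 to compound 3 (0.20 log units; that floor lies within the scatter), so this change has a floor and no true size, and that floor does not clear the scatter. Compound 2 stands at a limit and not at a number: the limit of > 120 umol/kg in this assay, at which 1 of the 3 values shown sits.

Chloro and bromo leave open what a group of another kind at this place would do, such as an amine or a carboxylic acid. Whether any replacement here moves the number beyond the scatter, in either direction, remains unanswered, as does the effect of any change elsewhere on the shared core.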